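Amide series: from compound 3 to compound 4

The source may hold more compounds than are shown below. What is called first, only, known or untested is meant among the compounds shown, and "the series" means these compounds.

Values in a toxicity assay on THP-1 cells (Homo sapiens) for inhibition; a higher number here means that more compound is tolerated, a lower number that less compound is tolerated:
- compound 1 `Cn1c(-c2ccccc2)cnc1NC(=O)c1ccc(F)cc1`: > 100000 nM
- compound 2 `Cc1cccc(C(=O)Nc2ncc(-c3ccccc3)n2C)c1`: > 50000 nM
- compound 3 `Cn1c(-c2ccccc2)cnc1NC(=O)c1cccc(Br)c1`: > 50000 nM

For the measured compounds named here, every value so far is a limit and not a number. Compound 3 stands at the limit of > 50000 nM in this assay, at which 2 of the 3 values shown sit. Compound 1 stands at the limit of > 100000 nM in this assay, at which 1 of the 3 values shown sits.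

The next compound, compound 4 `Cn1c(-c2ccccc2)cnc1NC(=O)c1ncc[nH]1`, carries 1H-imidazol-2-yl in place of 3-bromophenyl on a carbonyl carbon.

Going by the values given here, three measured steps bear on this change: a step that the two limits leave unreadable from compound 1 to compound 2, a step that the two limits leave unreadable from compound 1 to compound 3 and a step that the two limits leave unreadable from compound 2 to compound 3. None has a readable size, and none brings in a five-membered aromatic ring with 2 hetero atoms. The expectation therefore rests only on the limits, with no sign so far of a measurable value in this assay. No step beyond the scatter is expected, in either direction. The expected step is a step that the limit leaves unreadable from compound 3 to compound 4. Compound 4 is estimated at 60000 nM, with an expected range from 25000 nM to 100000 nM, and the result may well be another limit.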

Compound 4, half-maximal cytotoxic concentration: > 100000 nM
Compound 4: only a limit was reported; the forecaster's own chance of this, stated with the estimate: 75%; at least 1.6-fold (0.22 log units) between middle value and limit.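

In this assay compound 4 gives > 100000 nM, a limit and not a number. The steps to compound 4 from compound 1, compound 2 and compound 3 cannot be read. The compounds shown leave open whether any change on the carbonyl carbon shifts the half-maximal cytotoxic concentration, with all four values being limits.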